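Pentylthio chain: terminal ethyl exchanged for ethoxycarbonyl

The compounds below may be only part of what the source reports. "The series", "measured", "known", "first", "only" and "open" are said of these compounds alone.

Measured compounds:
- compound 1, `O=C(O)Cn1c(SCCCOc2ccccc2)nc2ccccc21`, in an assay on HEK293 cells for displacement of a labelled ligand from prostaglandin D2 receptor 2 (Homo sapiens) (a lower number here means a stronger inhibitor, a higher number a weaker inhibitor), gives 786 nM
- compound 2, `O=C(O)Cn1c(SCCCNc2ccccc2)nc2ccccc21`, in this assay gives 2690 nM
- compound 3, `CCCCCSc1nc2ccccc2n1CC(=O)O`, in this assay gives 1240 nM

Compound 3 stands second highest of the three numbers; its gap to compound 1 is within the scatter, its gap to compound 2 is beyond it. The three compounds share a core and differ only on a saturated chain carbon, three bonds along the chain from a sulfur: phenoxy, anilino or ethyl.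

Compound 4, `CCOC(=O)CCCSc1nc2ccccc2n1CC(=O)O`, is not yet measured. It differs from compound 3 in one place: ethoxycarbonyl in place of ethyl on a saturated chain carbon, three bonds along the chain from a sulfur.

Going by the values given here, the steps that bear on this position are a 1.6-fold higher number from compound 1 to compound 3 (0.20 log units; within the scatter), a 2.2-fold lower number from compound 2 to compound 3 (0.34 log units; beyond the scatter) and a 3.4-fold higher number from compound 1 to compound 2 (0.53 log units; beyond the scatter). All are modest or within the scatter, so this position has tolerated groups of quite different kind without large shifts. Among the compounds with values here, none of the measured compounds carries an ester or any acceptor at this place, so the ethoxycarbonyl is untested here.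

For compound 4 in this assay a step no larger than those seen, with a slight lean toward a higher number, is expected: a 1.3-fold higher number from compound 3 to compound 4 (0.11 log units; within the scatter). Compound 4 is estimated at 1600 nM, with a range from 500 nM to 5000 nM.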

Compound 4, half-maximal inhibitory concentration: 4410 nM
Compound 4: the middle estimate sits 2.8-fold (0.44 log units) below what was measured; measured number inside the range.
By their numbers in this assay, from the lowest: compounds 1 and 3 (each within the scatter of the next); then compounds 2 and 4 (each within the scatter of the next).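

In this assay ethoxycarbonyl in place of ethyl gives a 3.6-fold higher number from compound 3 to compound 4 (0.55 log units; beyond the scatter) and, set against phenoxy, it gives a 5.6-fold higher number from compound 1 to compound 4 (0.75 log units; beyond the scatter) as the widest step yet seen on this saturated chain carbon, so the position is less indifferent to its group than phenoxy and ethyl alone suggested. Against anilino the same group gives a 1.6-fold higher number from compound 2 to compound 4 (0.21 log units; within the scatter) and the four compounds now fall into two sets, with compound 1 and compound 3 giving the lower numbers and compound 2 and compound 4 the higher ones. A rule that larger groups give higher numbers fails on compound 1, whose phenoxy stays in the set with the ethyl of compound 3.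

Nothing available accounts for this division into two sets.

On these data alone, it remains open whether the step follows the carbonyl or the outer ethyl of the ester, which a carboxylic acid, a primary amide or a ketone at this place would help to separate. A longer chain carrying the same ethoxycarbonyl would show whether the step depends on how far the group stands from the sulfur.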